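Chloro-to-hydrogen step in a tetrazolyl amide series

A few compounds are considered here, and "the series" means these few. Any claim that something is new, unique, unknown or untested is made for them only; others in the source may bear on it.

Compound 1 `Cc1ccc(-c2cc(Cl)cc(C(=O)Nc3nn[nH]n3)n2)cc1` and compound 2 `CCCOc1cc(C(=O)Nc2nn[nH]n2)nc(-c2ccc(N)cc2)c1` have been run in a functional assay on the whole organism for inhibition, with Rattus norvegicus as the target, at a dose of 0.3 mg/kg by the oral route; on this read-out lower numbers stand for a weaker effect and higher numbers for a stronger effect at the one dose given. In this assay compound 1 gives 10% and compound 2 gives 7%. Compound 1 has the higher of the two numbers, but the gap to compound 2 lies within the scatter, so no order is drawn. Compound 3 `Cc1ccc(-c2cccc(C(=O)Nc3nn[nH]n3)n2)cc1` differs from compound 1 by hydrogen in place of chloro on an aromatic carbon. For the measured compounds named here, no step between measured compounds calibrates this change. Both measured numbers are low, so no step beyond the scatter is expected. The expected step is a number 2 percentage points lower from compound 1 to compound 3 (within the scatter). Compound 3 is estimated to give 8%, between -5% and 20%.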

Compound 3, a percentage reported as inhibition, in the whole organism at one dose (the size of the read-out at that dose, not a potency): 21%
Compound 3: the middle estimate sits 13 percentage points below what was measured; the whole stated range lies below it.
By their numbers in this assay, from the lowest: compounds 2 and 1 (each within the scatter of the next); then compound 3.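

In this assay, replacing the chloro opposite the ring nitrogen with hydrogen gives a number 11 percentage points higher from compound 1 to compound 3 (beyond the scatter), so this place on the core of compound 1 does not need the chloro for the effect at the one dose given. For the compounds shown here, this is the first single-place change whose step exceeds the scatter, though the step is modest. No data at hand explain the step.

On these data alone, how fluoro, methoxy or an amine would read at this place remains open. Also open, as far as these compounds go, is whether the step holds with a group other than 4-methylphenyl.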